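A Longer Branched Ester Against a Single Measured Step

The source may report more compounds than this note shows. Statements on the series, on what has been measured and on what is new or still open speak of the compounds shown alone.

In an ADME assay on Vero cells (Chlorocebus sabaeus) for cytotoxicity, read by MTT assay (a higher number here means a weaker inhibitor, a lower number a stronger inhibitor), two esters of the shared core have been measured so far. Compound 1 `CCC(C)CC(=O)OCC(C)(C)CC1=C(O)C(=O)c2ccccc2C1=O` gives 2300 nM, while compound 2 `CCCCCC(=O)OCC(C)(C)CC1=C(O)C(=O)c2ccccc2C1=O` gives 169000 nM, the higher of the two numbers.

Compound 3 `CCCCCCC(C)C(=O)OCC(C)(C)CC1=C(O)C(=O)c2ccccc2C1=O` differs from compound 2 in one place: 1-methylheptyl in place of pentyl on a carbonyl carbon. In words, it carries 1-methylheptyl in place of pentyl on a carbonyl carbon.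

Among the compounds with values here, only one measured step bears on this change. That step is a 73-fold higher number from compound 1 to compound 2 (1.87 log units; beyond the scatter), which is large and beyond the scatter, and it came with butyl in place of sec-butyl. Compound 3 also carries a branched group, so a move back towards the lower number of compound 1 seems likely. However, no measured compound has a chain as long as 1-methylheptyl, and a single pair establishes no pattern. Only part of the earlier step is therefore expected to return, and the uncertainty is wide.

The expected change in this assay is an 8.5-fold lower number from compound 2 to compound 3 (0.93 log units; beyond the scatter), towards a lower number. For compound 3 the estimated value is 20000 nM, with an expected range of 3000 nM to 120000 nM.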

Compound 3, half-maximal inhibitory concentration: 450 nM
For compound 3 the middle estimate is 44-fold (1.65 log units) above the measured one; the whole stated range lies above it.
By their numbers in this assay, from the lowest: compound 3; then compound 1; then compound 2.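

In this assay, within the data shown here, the place on a carbonyl carbon whose other neighbours are oxygen next to a carbonyl group proves more sensitive than the one earlier step could show: a 380-fold lower number from compound 2 to compound 3 (2.57 log units; beyond the scatter), with 1-methylheptyl in place of pentyl. The lowest number no longer belongs to the 2-methylbutyl group, since there is a 5.1-fold lower number from compound 1 to compound 3 (0.71 log units; beyond the scatter), with 1-methylheptyl in place of 2-methylbutyl. Among these three compounds, both branched groups give lower numbers than the unbranched pentyl of compound 2, and none goes against this, although three compounds are too few to establish a general pattern, and no evidence here accounts for the size of either step.

Compound 3 differs from compound 1 in both the length of its chain and the place of its methyl branch, so the compounds shown leave these two changes unseparated; an unbranched octyl chain and a 1-methylbutyl group would each bear on that question. They also leave open how this assay responds at the same place to a group of another kind, such as a cyclohexyl ring, an amine or a carboxylic acid.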